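Methyl for methoxy on the core of compound 3

The source may hold more compounds than are shown below. What is called first, only, known or untested is meant among the compounds shown, and "the series" means these compounds.

Measured compounds in a functional assay on the whole organism (strain Sprague-Dawley) for inhibition, with Rattus norvegicus as the target; on this read-out lower numbers stand for an effect already at smaller amounts and higher numbers for an effect only at larger amounts of compound:
- compound 1, `O=c1c(-c2nn[nH]n2)c[nH]c2c(Br)cccc12`: > 5 mg/kg (a limit of the assay, not a number)
- compound 2, `O=c1c(-c2nn[nH]n2)c[nH]c2c(F)cccc12`: 0.625 mg/kg
- compound 3, `COc1cccc2c(=O)c(-c3nn[nH]n3)c[nH]c12`: 0.15 mg/kg

Compound 3 holds the lowest number among the values shown in this assay; compound 2 comes nearest, at a 4.2-fold lower number from compound 2 to compound 3 (0.62 log units; beyond the scatter) above it. For compound 1 only a limit is recorded, (the limit of > 5 mg/kg in this assay, at which 1 of the 3 values shown sits).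

Compound 4 is `Cc1cccc2c(=O)c(-c3nn[nH]n3)c[nH]c12`. It differs from compound 3 in one place: methyl in place of methoxy on an aromatic carbon.

For the measured compounds named here, no measured step covers methyl directly. What bears on the change is the sequence at the same aromatic carbon: an at least 33-fold lower number from compound 1 to compound 3 (1.52 log units; beyond the scatter) and a 4.2-fold lower number from compound 2 to compound 3 (0.62 log units; beyond the scatter), together with an at least 8.0-fold lower number from compound 1 to compound 2 (0.90 log units; beyond the scatter). All three leave methoxy as the substituent with the lowest number; the step from fluoro to methoxy is modest, the step from bromo is large. Methyl sits in none of these, so the direction is read by analogy only: methoxy has given the best number, and its replacement is expected to move the number up, toward compound 2 rather than beyond it.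

For compound 4 the estimate is 0.4 mg/kg, with a range from 0.15 mg/kg to 1.25 mg/kg, which means an expected step of a 2.7-fold higher number from compound 3 to compound 4 (0.43 log units; beyond the scatter).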

Compound 4, minimum effective dose: > 5 mg/kg
Compound 4: a limit, no number; the forecaster's own chance of this, stated with the estimate: 10%; middle value at least 12-fold (1.09 log units) away from the limit.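

In this assay, methyl at this aromatic carbon, ortho to a fused ring, does not fall in with the two substituents that give a number, with an at least 33-fold higher number from compound 3 to compound 4 (1.52 log units; beyond the scatter) and an at least 8.0-fold higher number from compound 2 to compound 4 (0.90 log units; beyond the scatter). Until now, the series showed only that bromo stood apart from fluoro and methoxy; this change shows that removing the oxygen of methoxy and leaving its carbon is enough to reach the limit of the assay, so a small group at this position does not by itself preserve the effect. The step between compound 1 and compound 4 cannot be read, because both values are limits: the limit of > 5 mg/kg in this assay, at which 2 of the 4 values shown sit.

With only four substituents at one position, the compounds shown do not separate the part played by the oxygen from that of the whole methoxy group. As far as these compounds go, whether hydroxy, ethoxy, chloro or an amine at the same carbon would stay near compound 3 or join compound 4 at the limit remains open, as does how far compound 1 and compound 4 differ from each other.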